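Swapping the hydroxyphenyl for a pyrrole ring

The source may report more compounds than this note shows. Statements on the series, on what has been measured and on what is new or still open speak of the compounds shown alone.

Measured compounds:
- compound 1 `CC(=O)C(CSC(=S)N(C)C)CSC(=S)N(C)C` gives 890 nM in a functional assay on NCI-H460 cells (Homo sapiens) for inhibition, read by MTT assay, with a stated time of 72 h; a higher number here means a weaker inhibitor, a lower number a stronger inhibitor
- compound 2 `CN(C)C(=S)SCC(CSC(=S)N(C)C)C(=O)c1ccccc1` gives 1930 nM in this assay
- compound 3 `CN(C)C(=S)SCC(CSC(=S)N(C)C)C(=O)c1ccc(O)cc1` gives 30000 nM in this assay

Compound 3 stands at the weak end of this small set: its number is the highest of the three, with a 16-fold higher number from compound 2 to compound 3 (1.19 log units; beyond the scatter) and a 34-fold higher number from compound 1 to compound 3 (1.53 log units; beyond the scatter) marking the distance to the other two. Compound 4 `CN(C)C(=S)SCC(CSC(=S)N(C)C)C(=O)c1ccc[nH]1` differs from compound 3 in one place, with 1H-pyrrol-2-yl in place of 4-hydroxyphenyl on a carbonyl carbon.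

Going by the values given here, two measured steps bear on this change. The step of a 16-fold higher number from compound 2 to compound 3 (1.19 log units; beyond the scatter) shows that adding the hydroxy to the ring cost a great deal, and the step of a 2.2-fold higher number from compound 1 to compound 2 (0.34 log units; beyond the scatter) shows that the bare ring itself cost only a little against the methyl. Compound 4 drops the hydroxy but brings a ring that still carries a hydrogen-bond donor, so some but not all of the loss seen in compound 3 is expected to be recovered. Compound 4 is therefore expected to land around 6000 nM (range 1500 nM to 25000 nM), a step of a 5.0-fold lower number from compound 3 to compound 4 (0.70 log units; beyond the scatter) toward stronger inhibition.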

Compound 4, half-maximal inhibitory concentration: 97300 nM
Compound 4: the middle estimate sits 16-fold (1.21 log units) below what was measured, outside the stated range (above it).
By their numbers in this assay, from the lowest: compound 1; then compound 2; then compound 3; then compound 4.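

In this assay, taking away the 4-hydroxyphenyl did not win back strength: putting 1H-pyrrol-2-yl on the carbonyl carbon gives a 3.2-fold higher number from compound 3 to compound 4 (0.51 log units; beyond the scatter), so a smaller ring that also has a hydrogen-bond donor does not undo the loss seen with the hydroxy. The wider gaps, a 50-fold higher number from compound 2 to compound 4 (1.70 log units; beyond the scatter) and a 110-fold higher number from compound 1 to compound 4 (2.04 log units; beyond the scatter), show that this position tells aromatic rings sharply apart: both rings with a donor fall far behind the plain phenyl and the methyl. Still open, on these data alone, is how a furan or thiophene ring on the same carbonyl carbon, or an ethyl chain there, would compare, which could separate ring size from the donor. Nothing measured here accounts for these steps.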